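Methoxy on the anilino ring of a thiazole amide series

The source may hold more compounds than are shown below. What is called first, only, known or untested is meant among the compounds shown, and "the series" means these compounds.

Compound 1 `Cc1nc(SCC(=O)Nc2nc(-c3ccc(Cl)cc3)cs2)n(Nc2ccccc2)c1C` and compound 2 `Cc1ccc(Nn2c(SCC(=O)Nc3nc(-c4ccccc4)cs3)nc(C)c2C)cc1` share a core and differ at two outer rings. In a functional assay on SW-620 cells (Homo sapiens) for antiproliferative activity, read by sulforhodamine B assay, with a stated time of 48 h (on this read-out lower numbers stand for stronger inhibition of growth and higher numbers for weaker inhibition of growth), compound 1 gives 5500 nM, and compound 2 gives 8030 nM; the two numbers lie within the usual scatter of each other, so neither stands apart. Compound 3 `COc1ccc(Nn2c(SCC(=O)Nc3nc(-c4ccc(Cl)cc4)cs3)nc(C)c2C)cc1` has not been measured. Compared with compound 1 it carries methoxy in place of hydrogen on an aromatic carbon. Going by the values given here, with no measured pair showing this change, the step from compound 1 to compound 3 is expected to stay within the scatter, a 1.1-fold higher number from compound 1 to compound 3 (0.04 log units; within the scatter). Compound 3 is therefore estimated at 6000 nM, between 2500 nM and 15000 nM.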

Compound 3, concentration for 50% growth inhibition: 4780 nM
Estimate against measurement, compound 3: 1.3-fold (0.10 log units) above, within the range that was stated.
By their numbers in this assay, from the lowest: compounds 3, 1 and 2 (each within the scatter of the next).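

Going by these compounds alone, compound 1 and compound 3 form the first pair here that differs in one place, so the change can be read by itself. In this assay, methoxy in place of hydrogen, para to a large group on the anilino ring, gives a 1.2-fold lower number from compound 1 to compound 3 (0.06 log units; within the scatter) and so shows that this position tolerates methoxy. No measured evidence bears on this result.

As far as these compounds go, whether an amine, a carboxylic acid or a longer chain at this position would give a step beyond the scatter remains open. So does whether methoxy behaves the same way without the chlorine on the other outer ring.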